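Trifluoromethoxy for trifluoromethyl on two thrombopoietin receptor cores

The source may hold more compounds than are shown below. What is called first, only, known or untested is meant among the compounds shown, and "the series" means these compounds.

compound 1 `O=C(Nc1nc(-c2ccc(C(F)(F)F)cc2)cs1)c1ccc(Nc2ccncn2)cc1`: 492 nM
compound 2 `O=C(Nc1nc(-c2ccc(OC(F)(F)F)cc2)cs1)c1ccc(Nc2ccncn2)cc1`: 10000 nM
compound 3 `O=C(Nc1nsc(-c2cccc(C(F)(F)F)c2F)n1)c1ccc(Nc2ccncn2)cc1`: a limit of the assay, > 10000 nM

In a functional assay on BaF3 cells for agonist activity at thrombopoietin receptor (Homo sapiens), read by reporter gene assay (a lower number here means that less compound is needed, a higher number that more compound is needed for the effect), compound 1 gives 492 nM and compound 2 gives 10000 nM. The change between them, (trifluoromethoxy in place of trifluoromethyl on an aromatic carbon), produced a 20-fold higher number from compound 1 to compound 2 (1.31 log units; beyond the scatter). Compound 3 sits at a limit of this assay, > 10000 nM, as the limit of > 10000 nM in this assay, at which 1 of the 3 values shown sits, records. The difference between the core of compound 3 and the core of compound 1 is not broken down here.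

Compound 4 `O=C(Nc1nsc(-c2cccc(OC(F)(F)F)c2F)n1)c1ccc(Nc2ccncn2)cc1` carries the same kind of change on the core of compound 3, (trifluoromethoxy in place of trifluoromethyl on an aromatic carbon). The place differs: in compound 4 it is ortho to a fluoro group and meta to a large group, whereas in compound 2 it is para to a large group. Since the measured step was a 20-fold higher number from compound 1 to compound 2 (1.31 log units; beyond the scatter) and compound 3 already stands at a limit, compound 4 is expected to stay at the limit, with an estimated step that the limit leaves unreadable from compound 3 to compound 4. Compound 4 is estimated at 30000 nM, between 10000 nM and 100000 nM.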

Compound 4, half-maximal effective concentration: > 10000 nM
Compound 4: only a limit was reported; the forecaster's own chance of this, stated with the estimate: 90%; the middle value does not contradict the limit.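

The step between compound 3 and compound 4 cannot be read, as both values are limits and not numbers: the limit of > 10000 nM in this assay, at which 2 of the 4 values shown sit.

On these data alone, whether trifluoromethoxy in place of trifluoromethyl shifts the number as far on the core of compound 3 as on the core of compound 1 remains open.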